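Working notes on the carbonate series, compounds 1 to 4

This account rests on a few compounds, and the source may have more. Where it says the series, first, only, none or still open, it means among the compounds named here.

Compound 3 `Cc1cn(C2CC(N=[N+]=[N-])C(COC(=O)OCCCCCCO)O2)c(=O)[nH]c1=O` stands highest of the three numbers in a physicochemical assay for lipophilicity; on this read-out lower numbers stand for lower lipophilicity and higher numbers for higher lipophilicity; compound 3 gives 0.08. Compound 2 `Cc1cn(C2CC(N=[N+]=[N-])C(COC(=O)OCCCCCO)O2)c(=O)[nH]c1=O` gives -0.45, and compound 1 `Cc1cn(C2CC(N=[N+]=[N-])C(COC(=O)OCCCO)O2)c(=O)[nH]c1=O` gives -0.98. Across these, a number 0.53 log units higher from compound 1 to compound 2 (beyond the scatter), a number 0.53 log units higher from compound 2 to compound 3 (beyond the scatter) and a number 1.06 log units higher from compound 1 to compound 3 (beyond the scatter). Compound 4 `Cc1cn(C2CC(N=[N+]=[N-])C(COC(=O)OCCCN)O2)c(=O)[nH]c1=O` differs from compound 3 by amino in place of 3-hydroxypropyl on a saturated chain carbon, three bonds along the chain from an oxygen next to a carbonyl group. The chain returns to the length of compound 1, so the step that gave a number 1.06 log units higher from compound 1 to compound 3 (beyond the scatter) bears on it in reverse; the measured steps say nothing about amino against hydroxy, and that part is left open. For compound 4 the expected step is a number 1.18 log units lower from compound 3 to compound 4 (beyond the scatter). The estimate for compound 4 is -1.1, in the range -1.9 to -0.5.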

Compound 4, partition coefficient: -0.93
Estimate against measurement, compound 4: 0.17 log units below; the range from low to high includes it.
By their numbers in this assay, from the lowest: compounds 1 and 4 (each within the scatter of the next); then compound 2; then compound 3.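

In this assay, for the compounds shown here, amino in place of hydroxy on this saturated chain carbon reads a number 0.05 log units higher from compound 1 to compound 4 (within the scatter) and the two end groups cannot be told apart at this chain length, a comparison the earlier compounds did not offer. The steps of a number 0.48 log units lower from compound 2 to compound 4 (beyond the scatter) and a number 1.01 log units lower from compound 3 to compound 4 (beyond the scatter) then follow the chain length already seen among the hydroxy compounds. No supporting data on hand explain the result.

As far as these compounds go, whether amino and hydroxy also match on a longer chain stays open. So does how a carboxylic acid or a methoxy group would read on this carbon.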